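Adding a methyl to the amide of compound 3

The compounds below may be only part of what the source reports. "The series", "measured", "known", "first", "only" and "open" are said of these compounds alone.

Three compounds share one core and differ in a single group. In an ADME assay on microsomes from liver (Homo sapiens) for metabolic stability, read by LC-MS, using NADPH, with stated times of 5 min and 30 min, tested at 1 uM (on this read-out higher numbers stand for fast clearance and lower numbers for slow clearance), compound 1 `Cc1nc(CO)ccc1-c1cnc(NCc2c(F)ccc3c2CCO3)c2cn[nH]c(=O)c12` gives 11 mL.min-1.g-1, compound 2 `Cc1nc(CN(C)C)ccc1-c1cnc(NCc2c(F)ccc3c2CCO3)c2cn[nH]c(=O)c12` gives 13 mL.min-1.g-1 and compound 3 `CNC(=O)c1ccc(-c2cnc(NCc3c(F)ccc4c3CCO4)c3cn[nH]c(=O)c23)c(C)n1` gives 23 mL.min-1.g-1. Within the data shown here, only one measured step, a 2.1-fold higher number from compound 1 to compound 3 (0.32 log units; beyond the scatter), lies beyond the usual scatter, and it is modest. The steps of a 1.8-fold higher number from compound 2 to compound 3 (0.25 log units; within the scatter) and a 1.2-fold higher number from compound 1 to compound 2 (0.07 log units; within the scatter) lie within that scatter. Compound 3 thus stands clear of compound 1 but not of compound 2.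

Compound 4 `Cc1nc(C(=O)N(C)C)ccc1-c1cnc(NCc2c(F)ccc3c2CCO3)c2cn[nH]c(=O)c12` changes one place in compound 3: methyl in place of hydrogen on an amide-type nitrogen, so that methylcarbamoyl becomes dimethylcarbamoyl (methyl in place of hydrogen on an amide-type nitrogen). Among the measured compounds shown here, no measured pair makes this exact change, so the three steps above are only indirect guides. For the measured compounds named here, since the one step beyond the scatter is just a 2.1-fold higher number from compound 1 to compound 3 (0.32 log units; beyond the scatter), a large change is not expected from a single added methyl. The expectation is a slight lean upward that stays within the scatter. The expected step is a 1.2-fold higher number from compound 3 to compound 4 (0.09 log units; within the scatter). For compound 4 the estimated value is 28 mL.min-1.g-1, with an expected range from 13 mL.min-1.g-1 to 55 mL.min-1.g-1.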

Compound 4, intrinsic clearance in microsomes: 19 mL.min-1.g-1
The estimate for compound 4 lay 1.5-fold (0.17 log units) above the measured number; the range from low to high includes it.
By their numbers in this assay, from the lowest: compounds 1, 2, 4 and 3 (each within the scatter of the next, the first and the last beyond it).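

In this assay the amide hydrogen of compound 3 can be replaced by methyl without a readable effect, as a 1.2-fold lower number from compound 3 to compound 4 (0.08 log units; within the scatter) is the whole of the step at this amide-type nitrogen. The added methyl also alters how the amide compares with the other groups: compound 3 stood clear of compound 1, whereas a 1.7-fold higher number from compound 1 to compound 4 (0.24 log units; within the scatter) does not separate dimethylcarbamoyl from hydroxymethyl. Likewise, a 1.5-fold higher number from compound 2 to compound 4 (0.16 log units; within the scatter) does not separate dimethylcarbamoyl from (dimethylamino)methyl, so compound 4 cannot be told apart from either compound on this read-out, even though compound 3 remains apart from compound 1.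

Still open, as far as these compounds go, is whether a longer chain on the amide nitrogen, such as ethyl, a plain carbamoyl group with both hydrogens, or a carboxylic acid at this aromatic carbon would stay within the same narrow band of clearance numbers. Nothing measured here gives a reason for these results.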